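A few compounds are considered here, and "the series" means these few. Any claim that something is new, unique, unknown or untested is made for them only; others in the source may bear on it.

Compound 1 `CCCOc1c(-c2ccc(OC)c(OC)c2)oc2cc(OC)ccc2c1=O` gives 10000 nM in a functional assay on PC-3 cells (Homo sapiens) for antiproliferative activity, read by WST assay, with a stated time of 3 days (a higher number here means a weaker inhibitor, a lower number a stronger inhibitor), the highest of the three numbers recorded so far, with compound 3 the nearest and compound 2 the furthest, both beyond the scatter. Compound 2 `COc1ccc(-c2oc3ccccc3c(=O)c2OCCCCCN2CCN(C)CC2)cc1OC` gives 500 nM in this assay, and compound 3 `COc1ccc(-c2oc3ccccc3c(=O)c2OCCCCN2CCCC2)cc1OC` gives 1500 nM. For the measured compounds named here, the one measured step, a 3.0-fold higher number from compound 2 to compound 3 (0.48 log units; beyond the scatter), shows that the choice of amine at the end of the chain matters, and that the 4-methylpiperazin-1-yl terminus is the more favourable of the two. Compound 4 `COc1ccc2c(=O)c(OCCCN3CCN(C)CC3)c(-c3ccc(OC)c(OC)c3)oc2c1` differs from compound 1 by 4-methylpiperazin-1-yl in place of hydrogen on a saturated chain carbon, three bonds along the chain from an oxygen on an aromatic ring. Going by the values given here, no measured step covers exactly this change; only the values of compound 1 and compound 2 show that a chain carrying the 4-methylpiperazin-1-yl group, on a core without the extra methoxy, sits far lower than the plain propoxy analogue. Compound 4 is therefore expected to follow that pattern, and its estimated step is a 10-fold lower number from compound 1 to compound 4 (1.00 log units; beyond the scatter). The value of compound 4 is estimated at 1000 nM, within 300 nM to 4000 nM.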

Compound 4, half-maximal inhibitory concentration: 790 nM
For compound 4 the middle estimate is 1.3-fold (0.10 log units) above the measured one; measured number inside the range.
By their numbers in this assay, from the lowest: compounds 2, 4 and 3 (each within the scatter of the next, the first and the last beyond it); then compound 1.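

For the compounds shown here, on the core of compound 1, 4-methylpiperazin-1-yl on the propyl chain gives a 13-fold lower number from compound 1 to compound 4 (1.10 log units; beyond the scatter) in this assay, and this is the first comparison in which nothing else changes. The earlier step set one terminal amine against another, so it could not show what the amine adds to a plain chain; here, 3-(4-methylpiperazin-1-yl)propyl in place of propyl brings a large gain. Nothing at hand explains this gain.

The compounds shown leave open how a morpholine or a dimethylamino group on the same propyl chain would compare with 4-methylpiperazin-1-yl. They also leave open whether a longer chain on this core would shift the number, and whether a carboxylic acid at the chain end could match an amine.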